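Adding a Hydroxy Group to a Five-Ring Bridged Core

This account rests on a few compounds, and the source may have more. Where it says the series, first, only, none or still open, it means among the compounds named here.

Compound 1 `C=C1C[C@]23C[C@@]1(O)CC[C@H]2[C@@]12C=C[C@H](O)[C@](C)(C(=O)O1)[C@H]2[C@@H]3C(=O)OC` gives > 100 ug/mL in a functional assay on BIU87 cells (Homo sapiens) for cytotoxicity, read by MTT assay (on this read-out lower numbers stand for stronger inhibition and higher numbers for weaker inhibition), which is a limit of the assay and not a number.
Compound 2 `C=C1C[C@]23C[C@@]1(OC(C)=O)CC[C@H]2[C@@]12C=C[C@H](OC(C)=O)[C@](C)(C(=O)O1)[C@H]2[C@@H]3C(=O)OCc1ccccc1` gives > 100 ug/mL in this assay, again a limit.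
Compound 3 `C=C1[C@H](O)[C@]23C[C@@]1(O)CC[C@H]2[C@@]12C=C[C@H](O)[C@](C)(C(=O)O1)[C@H]2[C@@H]3C(=O)OC` gives > 100 ug/mL in this assay, also a limit.

All three measured values sit at the same place, as the limit of > 100 ug/mL in this assay, at which 3 of the 3 values shown sit, records. Compound 1 and compound 3 differ in one spot: hydroxy in place of hydrogen on a saturated ring carbon. The step from compound 1 to compound 3 is a step that the two limits leave unreadable from compound 1 to compound 3, so the effect of this change on cytotoxicity cannot be read from these two compounds. Compound 2 has a different core, and the difference between the core of compound 2 and the core of compound 1 is not broken down here.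

Compound 4 `C=C1[C@H](O)[C@]23C[C@@]1(OC(C)=O)CC[C@H]2[C@@]12C=C[C@H](OC(C)=O)[C@](C)(C(=O)O1)[C@H]2[C@@H]3C(=O)OCc1ccccc1` has not yet been measured. It differs from compound 2 by hydroxy in place of hydrogen on a saturated ring carbon. Within the data shown here, this is the same kind of change as the one from compound 1 to compound 3, but not the same: in compound 4 the place is two ring bonds from the ring atom that bears an acetoxy group (4 heavy atoms), whereas in compound 3 that ring atom bears a hydroxy group (1 heavy atom).

In this assay the step from compound 2 to compound 4 is expected to be a number no higher from compound 2 to compound 4 (the limit leaves the size open), essentially none, because the limit of > 100 ug/mL in this assay, at which 3 of the 3 values shown sit, shows every measured value at the limit. Compound 4 is accordingly expected to give about 100 ug/mL, somewhere from 50 ug/mL to 300 ug/mL, most likely reported once more as a limit rather than a number.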

Compound 4, half-maximal inhibitory concentration: > 100 ug/mL
Compound 4 was reported as a limit (the forecaster's own chance of this, stated with the estimate: 85%); the middle value lies on the limit itself.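

Compound 2 and compound 4 are both reported as limits of the assay and not as numbers, so no step can be read between them, and the same holds for the whole set: the limit of > 100 ug/mL in this assay, at which 4 of the 4 values shown sit. The compounds shown leave open whether hydroxy in place of hydrogen on this saturated ring carbon changes cytotoxicity at all, and what number any of them would give in this assay.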